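Extending the acid chain of compound 2

This account rests on a few compounds, and the source may have more. Where it says the series, first, only, none or still open, it means among the compounds named here.

In a functional assay for inhibition, with Homo sapiens as the target (on this read-out lower numbers stand for stronger inhibition and higher numbers for weaker inhibition), compound 2 `O=C(O)CCc1cc(Cc2cccnc2)cc2c1CCC(NS(=O)(=O)c1ccc(Cl)cc1)C2` gives 7 nM, the lowest of the three measured numbers. Compound 1 `O=C(O)CCc1cc(-c2cccnc2)cc2c1CCC(NS(=O)(=O)c1ccc(Cl)cc1)C2` gives 670 nM, and compound 3 `Cc1c(Cc2cccnc2)cc2c(c1CCC(=O)O)CCC(NS(=O)(=O)c1ccc(Cl)cc1)C2` gives 610 nM. Two single changes connect these compounds. With (pyridin-3-yl)methyl in place of pyridin-3-yl on an aromatic carbon, the data show a 96-fold lower number from compound 1 to compound 2 (1.98 log units; beyond the scatter). With methyl in place of hydrogen on an aromatic carbon, they show an 87-fold higher number from compound 2 to compound 3 (1.94 log units; beyond the scatter). Both steps are large, so within these three compounds a single small change can shift this assay strongly in either direction.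

Compound 4 `O=C(O)CCC/C=C\c1cc(Cc2cccnc2)cc2c1CCC(NS(=O)(=O)c1ccc(Cl)cc1)C2` carries 5-carboxypent-1-en-1-yl in place of 2-carboxyethyl on an aromatic carbon. Neither measured step changes this chain, so neither gives a direct size for the new step. They show only that the series can respond sharply. With compound 2 already at 7 nM, a higher number seems more likely than a further drop, although the size remains poorly defined. The expected change is a 5.7-fold higher number from compound 2 to compound 4 (0.76 log units; beyond the scatter), toward weaker inhibition and probably smaller than either measured step. Compound 4 is estimated at 40 nM, with an expected range from 6 nM to 250 nM.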

Compound 4, half-maximal inhibitory concentration: 90 nM
The estimate for compound 4 lay 2.3-fold (0.35 log units) below the measured number; low and high end bracket the measured number.
By their numbers in this assay, from the lowest: compound 2; then compound 4; then compounds 3 and 1 (each within the scatter of the next).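

In this assay, going by these compounds alone, 5-carboxypent-1-en-1-yl in place of 2-carboxyethyl on an aromatic carbon gives a 13-fold higher number from compound 2 to compound 4 (1.11 log units; beyond the scatter) and is the only measured change to the acid chain itself. This position, ortho to a fused ring, therefore responds to the chain attached there even when the acid group is kept and the count of one hydrogen-bond donor and one hydrogen-bond acceptor stays the same, yet compound 4 still reads 90 nM with a chain of 8 heavy atoms in place of 5. The lengthened chain thus weakens inhibition without removing it, which adds a third large step to the two seen at other positions on the shared core. Nothing available accounts for the size of this step.

Chain length and the double bond change together here, so the saturated 5-carboxypentyl chain or a shorter 3-carboxypropyl chain would be needed to separate the two. From the compounds shown here alone, the role of the carboxylic acid at this position also stays open, and an amide or a tetrazole in its place would address that, as would the other geometry of the double bond for the alkene.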